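This account rests on a few compounds, and the source may have more. Where it says the series, first, only, none or still open, it means among the compounds named here.

Measured compounds in a functional assay on cardiac atrium for agonist activity at histamine H2 receptor (Cavia porcellus); on this read-out lower numbers stand for lower potency and higher numbers for higher potency (the scale is a negative logarithm):
compound 1 `N=C(NCCCc1c[nH]cn1)NCCC(c1ccc(Cl)cc1)c1ccccn1` gives 7.84
compound 2 `N=C(NCCCc1c[nH]cn1)NCCC(c1cccc(F)c1)c1ccccn1` gives 7.88

Compound 2 stands at the higher of the two numbers, but its step from compound 1, a number 0.04 log units higher from compound 1 to compound 2 (within the scatter), is within the scatter, so the two compounds are not separated on this read-out. That step exchanges one substituted phenyl for another on the saturated chain carbon bound to an aromatic carbon and a saturated chain carbon.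

Compound 3 `N=C(NCCCc1c[nH]cn1)NCCC(c1cc(F)cc(F)c1)c1ccccn1` is not yet measured. The change from compound 2 is fluoro in place of hydrogen on an aromatic carbon; the new fluoro sits on an aromatic carbon of a six-membered aromatic ring of carbon only, meta to a fluoro group and meta to a large group.

For the measured compounds named here, the only step available on this ring, from compound 1 to compound 2, was within the scatter, and it alters substitution on the same ring. Going by the values given here, no step adds a second substituent to it, so the expectation rests on that single step alone. A step of about a number 0.08 log units lower from compound 2 to compound 3 (within the scatter) is expected, that is, none beyond the scatter. Compound 3 is therefore estimated at 7.8, with a range from 7.3 to 8.3.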

Compound 3, negative logarithm of the half-maximal effective concentration: 8.05
Compound 3: middle estimate off by 0.25 log units, on the low side; low and high end bracket the measured number.
By their numbers in this assay, from the lowest: compounds 1, 2 and 3 (each within the scatter of the next).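

In this assay, for the compounds shown here, the change from 3-fluorophenyl to 3,5-difluorophenyl gives the first direct reading of a fluoro added to a ring that already carries one: a number 0.17 log units higher from compound 2 to compound 3 (within the scatter). Set against the 4-chlorophenyl, the same 3,5-difluorophenyl reads a number 0.21 log units higher from compound 1 to compound 3 (within the scatter), so all three substitution patterns on this ring remain unseparated on this read-out, and a second fluoro at this place leaves the potency within the scatter of both earlier compounds. No accompanying measurement bears on this result, so nothing beyond these numbers can be said about it.

All three ring patterns shown carry only halogens, so it remains open whether an amine, a carboxylic acid or a methoxy group on an aromatic carbon of this ring would move the number beyond the scatter. The unsubstituted phenyl is also absent from the compounds shown, which leaves no baseline for judging what the halogens contribute at all.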